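The source may hold more compounds than are shown below. What is called first, only, known or untested is meant among the compounds shown, and "the series" means these compounds.

Compound 1 `COc1ccc(-c2cncnc2-c2cc(OC)c(OC)c(OC)c2)cc1O` carries a 3-hydroxy-4-methoxyphenyl group on the shared core, and in a functional assay on SiHa cells (Homo sapiens) for antiproliferative activity, read by CCK-8 assay, with a stated time of 72 h (on this read-out lower numbers stand for stronger inhibition and higher numbers for weaker inhibition), compound 1 gives 2750 nM. Among the three compounds measured so far this is the lowest number. Compound 2 `COc1ccc(-c2cncnc2-c2cc(OC)c(OC)c(OC)c2)cc1F` differs only by fluoro in place of hydroxy on an aromatic carbon; compound 2 gives 3340 nM, and the step of a 1.2-fold higher number from compound 1 to compound 2 (0.08 log units; within the scatter). Going by the values given here, compound 3 `COc1cc(-c2ncncc2-c2ccc(C(=O)N(C)C)cc2)cc(OC)c1OC` no longer carries the 3-hydroxy-4-methoxyphenyl group at all; compound 3 gives 20200 nM, a much higher number than compound 1, though no single step for that pair is available.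

Compound 4 `COc1cc(-c2ncncc2-c2ccc(Br)cc2)cc(OC)c1OC` has not yet been measured. It differs from compound 1 as follows: 4-bromophenyl in place of 3-hydroxy-4-methoxyphenyl on an aromatic carbon. Among the compounds with values here, the only measured step, from compound 1 to compound 2, touched just the hydroxy and stayed within the scatter, so it says little about removing the whole group. The comparison of compound 1 with compound 3 shows that the number can rise steeply when this group is gone. For compound 4 the expected step is therefore a 2.9-fold higher number from compound 1 to compound 4 (0.46 log units; beyond the scatter), toward a higher number. Compound 4 is estimated at 8000 nM, with a likely range from 3000 nM to 25000 nM.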

Compound 4, half-maximal inhibitory concentration: 2960 nM
For compound 4 the middle estimate is 2.7-fold (0.43 log units) above the measured one, outside the stated range (below it).
By their numbers in this assay, from the lowest: compounds 1, 4 and 2 (each within the scatter of the next); then compound 3.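

In this assay, replacing the whole 3-hydroxy-4-methoxyphenyl group with 4-bromophenyl gives a 1.1-fold higher number from compound 1 to compound 4 (0.03 log units; within the scatter), so a hydrogen-bond donor and hydrogen-bond acceptors on this ring are not needed to reach a number at this level. The comparison with the fluoro analogue reads the same way, with a 1.1-fold lower number from compound 2 to compound 4 (0.05 log units; within the scatter), so three differently substituted rings at this position cannot be told apart in this assay. The steep rise seen with compound 3 therefore goes with the dimethylcarbamoyl group rather than with the loss of the 3-hydroxy-4-methoxyphenyl group, since bromo in place of dimethylcarbamoyl gives a 6.8-fold lower number from compound 3 to compound 4 (0.83 log units; beyond the scatter), a change beyond the scatter.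

The data shown offer no measurement that explains why these different groups give such similar numbers. On these data alone, it also remains open whether an amine, a carboxylic acid or a plain hydrogen in the place of the bromo would keep the number at this level or raise it as the dimethylcarbamoyl group does.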